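This account rests on a few compounds, and the source may have more. Where it says the series, first, only, none or still open, it means among the compounds named here.

Of the compounds shown here, three have been measured in a physicochemical assay for lipophilicity, read by HPLC, with a stated time of 90 min, tested at 100 uM; on this read-out higher numbers stand for higher lipophilicity and lower numbers for lower lipophilicity. Compound 1 `O=C(Nc1ccc(C(F)(F)F)cc1)NC1CCN(C(=O)C2=COCC2)CC1` gives 3.37. Compound 2 `CC(C)C(=O)N1CCC(NC(=O)Nc2ccc(OC(F)(F)F)c(F)c2)CC1` gives 4.73, the highest of the three numbers, a gap beyond the usual scatter above both neighbours. Compound 3 `CC[C@H](C)C(=O)N1CCC(NC(=O)Nc2ccc(C(F)(F)F)cn2)CC1` gives 3.22, the lowest of the set. The next compound to examine is compound 4 `CCOC(=O)N1CCC(NC(=O)Nc2ccc(OC(F)(F)F)c(F)c2)CC1`, which differs from compound 2 in one place: ethoxy in place of isopropyl on a carbonyl carbon. Among the compounds with values here, no pair of measured compounds here shows the effect of such a swap, so the expectation rests on the size of the groups exchanged, which are matched in their count of heavy atoms. A shift from compound 2 to compound 4 of a number 0.23 log units lower from compound 2 to compound 4 (within the scatter) is expected, a small drop that stays within the scatter. For compound 4 the estimated value is 4.5, with a likely range from 4.1 to 4.9.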

Compound 4, partition coefficient: 5.94
The estimate for compound 4 lay 1.44 log units below the measured number; measured number outside the range, above it.
By their numbers in this assay, from the lowest: compounds 3 and 1 (each within the scatter of the next); then compound 2; then compound 4.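

Ethoxy in place of isopropyl on a carbonyl carbon gives in this assay a number 1.21 log units higher from compound 2 to compound 4 (beyond the scatter) as the first single-place step in this set. The two groups have the same count of heavy atoms, so at this position, a count of heavy atoms alone does not settle the number. Nothing measured here accounts for the size of this step.

From the compounds shown here alone, it remains open whether the same swap gives a similar step on the core of compound 1 or compound 3. Going by these compounds, how methoxy, a longer chain such as butoxy, or a dimethylamino group on this carbonyl carbon would compare with ethoxy also remains open.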